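The source may report more compounds than this note shows. Statements on the series, on what has been measured and on what is new or still open speak of the compounds shown alone.

Three compounds built on one shared core have been compared in a functional assay on the whole organism (strain Swiss) with Mus musculus as the target, in the maximal electroshock model, with a stated time of 0.25 h, at a dose of 300 mg/kg by the intraperitoneal route; on this read-out higher numbers stand for a stronger effect at the one dose given and lower numbers for a weaker effect. Compound 1 `COc1cccc(N2CCN(C(=O)C(C)N3C(=O)CCC3=O)CC2)c1` gives 75%. Compound 2 `CCC(C(=O)N1CCN(c2cccc(OC)c2)CC1)N1C(=O)CCC1=O` gives 25%. Compound 3 `CCC(C(=O)N1CCN(c2ccc(F)cc2)CC1)N1C(=O)CCC1=O` gives 0%, the lowest of the three. Compound 1 differs from compound 2 by hydrogen in place of methyl on a saturated chain carbon, two bonds along the chain from an amide-type nitrogen in a ring and a carbonyl carbon, and the step of a number 50 percentage points higher from compound 2 to compound 1 (beyond the scatter). Compound 3 differs from compound 2 in the aromatic group on the ring nitrogen, by 4-fluorophenyl in place of 3-methoxyphenyl on an amine nitrogen in a ring, and the step of a number 25 percentage points lower from compound 2 to compound 3 (beyond the scatter). Compound 4 `CC(C(=O)N1CCN(c2ccc(F)cc2)CC1)N1C(=O)CCC1=O` has not yet been measured; it differs from compound 3 by hydrogen in place of methyl on a saturated chain carbon, two bonds along the chain from an amide-type nitrogen in a ring and a carbonyl carbon, the same change at the same place that turns compound 2 into compound 1. An upward step is expected from compound 3 to compound 4, about a number 40 percentage points higher from compound 3 to compound 4 (beyond the scatter), because a number 50 percentage points higher from compound 2 to compound 1 (beyond the scatter) in the pair that carries the other aromatic group. On these data alone, this rests on a single earlier step, and whether the change works the same way with the 4-fluorophenyl group present is exactly what remains untested. Compound 4 is therefore expected to reach about 40%, within a range from 10% to 75%.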

Compound 4, a percentage reported as activity, at one dose (the size of the read-out at that dose, not a potency): 100%
Compound 4: middle estimate off by 60 percentage points, on the low side; the whole stated range lies below it.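

In this assay, hydrogen in place of methyl at this chain carbon gave a number 100 percentage points higher from compound 3 to compound 4 (beyond the scatter), so the direction of the earlier step carried over to the core with the 4-fluorophenyl group, but its size did not: the same change on two cores in this assay, a number 50 percentage points higher (beyond the scatter) from compound 2 to compound 1 and a number 100 percentage points higher (beyond the scatter) from compound 3 to compound 4, 50 percentage points apart, beyond the scatter of two such steps

The swap of aromatic group did not even keep its direction, giving a number 25 percentage points higher from compound 1 to compound 4 (beyond the scatter) where it had lowered the number on the other pair: the same change on two cores in this assay, a number 25 percentage points lower (beyond the scatter) from compound 2 to compound 3 and a number 25 percentage points higher (beyond the scatter) from compound 1 to compound 4, 50 percentage points apart, beyond the scatter of two such steps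

These two pairs show that in this series a step measured on one core cannot be moved to another as a fixed amount, but they give no general rule, do not explain the difference, and, as read-outs at one dose, say nothing about potency.

On these data alone, it remains open whether the same change keeps its upward direction with other groups on the ring nitrogen, such as a plain phenyl or a chlorophenyl. As far as these compounds go, how the read-out responds to a longer chain, or to an amine, at the same chain carbon is also open.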